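Reducing the Formyl Group: From Compound 1 to Compound 3

A few compounds are considered here, and "the series" means these few. Any claim that something is new, unique, unknown or untested is made for them only; others in the source may bear on it.

Compound 1 `CC1(C)O[C@@H]2CC[C@](C)(O)[C@H](CCC3C(C=O)=CCC4C(CC[C@@]4(C)O)C3(C)C)[C@@]2(C)CCC1=O` and compound 2 `CC1=C(CC[C@@H]2[C@@]3(C)CC[C@@H](O)C(C)(C)O[C@@H]3CC[C@]2(C)O)[C@](C)(C/C=C/C(C)(C)O)[C@H](O)CC1` have both been tested in a functional assay on KB 3-1 cells (Homo sapiens) for cytotoxicity, read by MTT assay, with a stated time of 68 h, tested at 5 uM; on this read-out higher numbers stand for weaker inhibition and lower numbers for stronger inhibition. Compound 1 gives 5.6 nM, the lower of the two numbers, though the gap to compound 2, which gives 7.8 nM, lies within the scatter. Compound 3 `CC1(C)O[C@@H]2CC[C@](C)(O)[C@H](CCC3C(CO)=CCC4C(CC[C@@]4(C)O)C3(C)C)[C@@]2(C)CCC1=O` has not yet been measured in this assay. It differs from compound 1 by hydroxymethyl in place of formyl on a double-bonded ring carbon. Going by the values given here, no measured pair shows this change, so its effect cannot be read from the data. For compound 3 a modest weakening is expected, the step being a 2.7-fold higher number from compound 1 to compound 3 (0.43 log units; beyond the scatter). Compound 3 is estimated at 15 nM, with a range from 5 nM to 60 nM.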

Compound 3, half-maximal inhibitory concentration: 6.3 nM
Compound 3: middle estimate off by 2.4-fold (0.38 log units), on the high side; measured number inside the range.
By their numbers in this assay, from the lowest: compounds 1, 3 and 2 (each within the scatter of the next).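

In this assay, hydroxymethyl in place of formyl on this double-bonded ring carbon gives a 1.1-fold higher number from compound 1 to compound 3 (0.05 log units; within the scatter), so the two compounds cannot be told apart. In this pair, then, the formyl group is not required for the cytotoxic read-out, and the change can be made at this position without a step beyond the scatter. No available evidence bears on this result. The compounds shown leave open how this position responds to a carboxylic acid, an aminomethyl group or a plain methyl group. They also leave open whether the oxygen of the substituent is needed at all.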